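A few compounds are considered here, and "the series" means these few. Any claim that something is new, unique, unknown or untested is made for them only; others in the source may bear on it.

Compound 1 `CCc1cnc(N2CCC(c3coc4c(N5CCc6cc(S(C)(=O)=O)ccc65)ncnc34)CC2)nc1` gives 41 nM in a functional assay on cells for agonist activity at Glucose-dependent insulinotropic receptor (Homo sapiens), read by a luciferase reporter, with a stated time of 4 h (on this read-out lower numbers stand for an effect already at smaller amounts and higher numbers for an effect only at larger amounts of compound), the lowest of the two numbers in view. Compound 2 `CC(C)(C)OC(=O)N1CCC(c2coc3c(Nc4ccc(S(C)(=O)=O)cc4F)ncnc23)CC1` gives 129 nM in this assay, a step beyond the scatter away from compound 1. Compound 3 `Cn1cc(C2CCN(C(=O)OC(C)(C)C)CC2)c2ncnc(Nc3ccc(S(C)(=O)=O)cc3F)c21` gives > 1000 nM in this assay, which is the limit of > 1000 nM in this assay, at which 1 of the 3 values shown sits, a limit and not a number. Compound 4 `CS(=O)(=O)c1ccc2c(c1)CCN2c1ncnc2c(C3CCN(c4ncc(F)cn4)CC3)coc12` differs from compound 1 by fluoro in place of ethyl on an aromatic carbon, para to a large group. Among the measured compounds shown here, no measured pair shows this change, so the step is expected to stay within or close to the scatter, as a 1.5-fold higher number from compound 1 to compound 4 (0.17 log units; within the scatter). Compound 4 is accordingly estimated at 60 nM in this assay, in a range from 20 nM to 200 nM.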

Compound 4, half-maximal effective concentration: 201 nM
Beside the measured number, compound 4's estimate is 3.4-fold (0.53 log units) below it, outside the stated range (above it).
By their numbers in this assay, from the lowest: compound 1; then compounds 2 and 4 (each within the scatter of the next). At a limit, above all of these: compound 3.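

Fluoro in place of ethyl on this aromatic carbon, para to a large group, gives a 4.9-fold higher number from compound 1 to compound 4 (0.69 log units; beyond the scatter) in this assay. Among the compounds shown here, this is the first comparison of compounds that differ in one place, and it shows that the group at this position matters to the read-out, with the 5-ethylpyrimidin-2-yl of compound 1 giving the lower number. Nothing shown gives a reason for this step. As far as these compounds go, whether the difference comes from losing ethyl or from gaining fluoro stays open. So does how a hydrogen, a methoxy group or a longer chain such as propyl would read at this position.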